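Replacing the side group of compound 3

A few compounds are considered here, and "the series" means these few. Any claim that something is new, unique, unknown or untested is made for them only; others in the source may bear on it.

- compound 1 `O=C(O)CC/C=C\CC1COC(c2cccnc2)OC1c1cccnc1` with 759 nM
- compound 2 `CSc1ccc(OC(C)(C)C2OCC(C/C=C\CCC(=O)O)C(c3cccnc3)O2)c([N+](=O)[O-])c1` with 4.47 nM
- compound 3 `COc1ccccc1OC(C)(C)C1OCC(C/C=C\CCC(=O)O)C(c2cccnc2)O1` with 224 nM

All three values come from a functional assay for inhibition, with Homo sapiens as the target (a higher number here means weaker binding, a lower number tighter binding), and compound 4 `Cc1ccc(SC(C)(C)C2OCC(C/C=C\CCC(=O)O)C(c3cccnc3)O2)c([N+](=O)[O-])c1` has yet to be measured there. Compound 3 stands in the middle of the three: at 224 nM it has a lower number than compound 1 and a higher number than compound 2, and both gaps lie beyond the scatter.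

The change to compound 4 is a group of 11 heavy atoms (7 carbon, 1 nitrogen, 2 oxygen, 1 sulfur; one six-membered aromatic ring of carbon only) in place of a group of 9 heavy atoms (7 carbon, 2 oxygen; one six-membered aromatic ring of carbon only), on a saturated chain carbon bound to two saturated chain carbons and a saturated ring carbon and the 2-methoxyphenoxy group leaves. Among the measured compounds shown here, one measured step bears on this, namely a 50-fold higher number from compound 2 to compound 3 (1.70 log units; beyond the scatter) which is large and beyond the scatter. In that step the group lost by compound 2 has the same atom counts as the group entering here, but it sits on an oxygen and is not the same group, so the parallel is only partial. A large step towards a lower number is therefore expected, somewhat smaller than that precedent, and the estimated change is a 19-fold lower number from compound 3 to compound 4 (1.27 log units; beyond the scatter) in this assay on this reasoning. Compound 4 is expected at an estimated 12 nM with a likely range from 3 nM to 50 nM as its bounds.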

Compound 4, dissociation constant: 158 nM
Beside the measured number, compound 4's estimate is 13-fold (1.12 log units) below it, and the stated range ends below it.
By their numbers in this assay, from the lowest: compound 2; then compounds 4 and 3 (each within the scatter of the next); then compound 1.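

In this assay a 1.4-fold lower number from compound 3 to compound 4 (0.15 log units; within the scatter) shows that, on this saturated chain carbon, the entering group and the 2-methoxyphenoxy group cannot be told apart. The earlier 50-fold higher number from compound 2 to compound 3 (1.70 log units; beyond the scatter) therefore does not carry over to every group with those atom counts and one six-membered aromatic ring of carbon only: compound 2 gives 4.47 nM and compound 4 gives 158 nM, although both hold a group of that size and both rings carry a nitro group. No measurement shown here gives a reason for this result.

The two groups of compound 2 and compound 4 differ both in the atom that links the ring, oxygen or sulfur, and in the other ring substituent, methylthio or methyl, so the compounds shown leave open which of these features goes with the lower number of compound 2. A 2-methoxyphenylthio group would bear on the link alone, and a methylthio-bearing ring joined through sulfur would bear on the two features together, while an amine in place of the nitro group remains an open question as well.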